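A few compounds are considered here, and "the series" means these few. Any claim that something is new, unique, unknown or untested is made for them only; others in the source may bear on it.

Values so far in a functional assay on MDA-MB-231 cells (Homo sapiens) for antiproliferative activity, read by MTT assay, with a stated time of 48 h (on this read-out higher numbers stand for weaker inhibition and lower numbers for stronger inhibition), are these:

Compound 1 `CCS(=O)(=O)N1CCN(c2ncnc3sc(-c4ccc(N5CCN(C)CC5)cc4)cc23)CC1` gives 7330 nM
Compound 2 `CN1CCN(c2ccc(-c3cc4c(N5CCN(S(=O)(=O)C6CC6)CC5)ncnc4s3)cc2)CC1` gives 11500 nM

Within the data shown here, on these numbers compound 2 has a single neighbour, and the only measured step is a 1.6-fold higher number from compound 1 to compound 2 (0.20 log units; within the scatter). That step puts cyclopropyl in place of ethyl on a sulfonyl sulfur.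

Compound 3 (`CCCNC(=O)N1CCN(c2ncnc3sc(-c4ccc(N5CCN(C)CC5)cc4)cc23)CC1`) has not yet been measured. The change leading to it is propylcarbamoyl in place of cyclopropylsulfonyl on an amine nitrogen in a ring and it puts propylcarbamoyl in place of cyclopropylsulfonyl on an amine nitrogen in a ring.

The measured step bears on this only in part, since it altered the group on the sulfonyl sulfur and kept the sulfonyl itself. Among the measured compounds shown here, no measured step replaces the whole cyclopropylsulfonyl group, so the data give no direction for this change. The expectation therefore rests on compound 2 at 11500 nM and compound 1 at 7330 nM, and no step beyond the scatter is expected. The expected move in this assay is a 1.6-fold lower number from compound 2 to compound 3 (0.22 log units; within the scatter) and it is held loosely. For compound 3 the estimated value is 7000 nM with an expected range from 2000 nM to 25000 nM as its limits.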

Compound 3, half-maximal inhibitory concentration: 8330 nM
Estimate against measurement, compound 3: 1.2-fold (0.08 log units) below; the range from low to high includes it.
By their numbers in this assay, from the lowest: compounds 1, 3 and 2 (each within the scatter of the next).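

In this assay, among these compounds, the propylcarbamoyl group gives the first change of the whole group on this amine nitrogen in a ring, rather than of the part on the sulfonyl sulfur alone: against cyclopropylsulfonyl it gives a 1.4-fold lower number from compound 2 to compound 3 (0.14 log units; within the scatter), and against ethylsulfonyl it gives a 1.1-fold higher number from compound 1 to compound 3 (0.06 log units; within the scatter). Both steps stay within the scatter, so the three compounds show that, at this position, a sulfonyl group can give way to a carbonyl-bearing chain with no ring and the read-out does not separate them, even though the entering group differs in its atoms and in its count of hydrogen-bond donors and acceptors. No measurement in hand offers an explanation for this lack of separation.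

The three compounds share everything outside this one group and all carry a sulfonyl or carbonyl on the nitrogen, so they leave open whether a plain alkyl chain, a free amine or a carboxylic acid placed there would move the number beyond the scatter. They also leave open whether a longer chain on the carbamoyl, or a phenyl ring in place of the propyl, would separate from these values.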